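A Methyl Added to Compound 2: Expected Antiproliferative Potency

This account rests on a few compounds, and the source may have more. Where it says the series, first, only, none or still open, it means among the compounds named here.

Of the compounds shown here, two have so far been measured in a functional assay on MCF7 cells (Homo sapiens) for antiproliferative activity, read by colorimetric assay and MTT assay, with a stated time of 48 h; on this read-out higher numbers stand for weaker inhibition and lower numbers for stronger inhibition. Compound 1 `Cc1ccc(S(=O)(=O)NC(=O)c2ccncc2)cc1` gives 14100 nM in this assay. Compound 2 `O=C(NS(=O)(=O)c1ccccc1)c1ccccn1` gives 10600 nM in this assay. Of the two numbers shown, compound 2 carries the lower one, but its gap to compound 1 lies within the scatter of repeated measurements, so the two cannot be told apart on this read-out.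

Compound 3 `Cc1ccc(S(=O)(=O)NC(=O)c2ccccn2)cc1` has not yet been measured. It differs from compound 2 in one place: methyl in place of hydrogen on an aromatic carbon. The entering methyl sits on an aromatic carbon of a six-membered aromatic ring of carbon only, para to a large group.

Within the data shown here, no measured step matches this change; compound 1 and compound 2 differ in more than one place. The account therefore expects the step of a 1.0-fold higher number from compound 2 to compound 3 (0.02 log units; within the scatter) in this assay to stay within the scatter, in no clear direction. Compound 3 is estimated at 11000 nM in this assay, with a range from 5000 nM to 25000 nM.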

Compound 3, half-maximal inhibitory concentration: 11800 nM
Compound 3: the middle estimate sits 1.1-fold (0.03 log units) below what was measured; low and high end bracket the measured number.
By their numbers in this assay, from the lowest: compounds 2, 3 and 1 (each within the scatter of the next).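

In this assay, methyl in place of hydrogen on an aromatic carbon, para to a large group, gives a 1.1-fold higher number from compound 2 to compound 3 (0.05 log units; within the scatter), so this position tolerates a methyl without any effect that can be told apart on this read-out. Among these compounds, compound 3 also supplies a one-place comparison that the earlier compounds lacked: pyridin-2-yl in place of pyridin-4-yl on a carbonyl carbon gives a 1.2-fold lower number from compound 1 to compound 3 (0.08 log units; within the scatter), so these two attachments cannot be told apart either. The compounds shown offer no evidence on what lies behind either result.

Going by these compounds, whether a methoxy group, a chlorine atom or a carboxylic acid at the same place would give a step beyond the scatter remains open. So does the outcome with pyridin-3-yl on the carbonyl carbon.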